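Benzylamino Replaces Pyrrolidine on the Shared Core

A few compounds are considered here, and "the series" means these few. Any claim that something is new, unique, unknown or untested is made for them only; others in the source may bear on it.

Compound 2 `O=C1C(N2CCCC2)=CC(=O)c2c1nc1n2[C@H]2OC[C@@H](O)[C@H]2OC1` was tested in a functional assay on HeLa cells (Homo sapiens) for inhibition, read by sulforhodamine B assay; a lower number here means a stronger inhibitor, a higher number a weaker inhibitor. In this assay compound 2 reaches only the limit > 16000 nM, which is a limit and not a number. Compound 1 `COc1ccccc1NC1=CC(=O)c2c(nc3n2[C@H]2OC[C@@H](O)[C@H]2OC3)C1=O` carries (2-methoxyphenyl)amino on the same double-bonded ring carbon, and in this assay compound 1 gives 7460 nM. Going by the values given here, the single measured step, an at least 2.1-fold higher number from compound 1 to compound 2 (0.33 log units; beyond the scatter), is therefore known only as a lower bound because of the limit of > 16000 nM in this assay, at which 1 of the 2 values shown sits.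

Compound 3 `O=C1C(NCc2ccccc2)=CC(=O)c2c1nc1n2[C@H]2OC[C@@H](O)[C@H]2OC1` has not yet been measured in this assay. Relative to compound 2 the change is benzylamino in place of pyrrolidin-1-yl on a double-bonded ring carbon. Among the compounds with values here, this change reverses the direction of the one measured step: an amino group bound through nitrogen bearing hydrogen, as in compound 1, returns in place of pyrrolidin-1-yl. Compound 3 is therefore expected to land near compound 1, at an estimated 9000 nM, within 3000 nM to 20000 nM. The expected step of an at least 1.7-fold lower number from compound 2 to compound 3 (0.24 log units; that floor lies within the scatter) is a move toward a stronger inhibitor, though compound 3 may itself end at the limit.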

Compound 3, half-maximal inhibitory concentration: 11000 nM
The estimate for compound 3 lay 1.2-fold (0.09 log units) below the measured number; low and high end bracket the measured number.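

With benzylamino on the double-bonded ring carbon, the position now holds a second measured group bound through a nitrogen bearing hydrogen. Exchanging 2-methoxyphenyl for benzyl on that amine nitrogen gives a 1.5-fold higher number from compound 1 to compound 3 (0.17 log units; within the scatter), so this assay does not tell these two groups apart. Replacing pyrrolidin-1-yl with benzylamino gives an at least 1.4-fold lower number from compound 2 to compound 3 (0.16 log units; that floor lies within the scatter), and this step stays a floor that shows no real gain over compound 2, because the value of compound 2 is a limit: the limit of > 16000 nM in this assay, at which 1 of the 3 values shown sits.

The compounds shown leave open whether the hydrogen on the nitrogen or the aromatic ring accounts for any difference from compound 2. A dimethylamino group, which has no hydrogen on its nitrogen, and a butylamino chain, which has no ring, on the same carbon would separate the two.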